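Diaryl sulfide imidazolines: ester replaces sulfonamide

A few compounds are considered here, and "the series" means these few. Any claim that something is new, unique, unknown or untested is made for them only; others in the source may bear on it.

The series shares one core, a diaryl sulfide carrying an imidazoline amine. Compound 1 `COc1ccc(Sc2ccc(NC3=NCCN3)cc2)cc1` has a methoxy group on the outer ring; in an assay (Rattus norvegicus) for binding affinity to prostacyclin receptor (Homo sapiens), read by radioligand binding (a lower number here means a stronger inhibitor, a higher number a weaker inhibitor), compound 1 gives 50.1 nM; 50.1 nM (2 entries), the same figure in both entries. Compound 2 `CS(=O)(=O)Nc1ccc(Sc2ccc(NC3=NCCN3)cc2)cc1` carries a methanesulfonamido group at the same place, and in this assay compound 2 gives 79.4 nM. The two values lie within the usual scatter of each other; nothing beyond that is shown. Compound 2 stands on this single number in this assay, with one further entry that reports no single number.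

Compound 3 `CCOC(=O)c1ccc(Sc2ccc(NC3=NCCN3)cc2)cc1` is the next target. The change from compound 2 is ethoxycarbonyl in place of methanesulfonamido on an aromatic carbon. Among the measured compounds shown here, no step between measured compounds covers this change, so the expectation rests only on what compound 1 and compound 2 show at this place: two different groups there, both acceptor-bearing, give close values. A step from compound 2 to compound 3 of a 1.4-fold higher number from compound 2 to compound 3 (0.14 log units; within the scatter) is expected, modest and toward weaker binding, but possibly within the scatter. Compound 3 is estimated at 110 nM, in the range 40 nM to 320 nM.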

Compound 3, inhibition constant: 50.1 nM
The estimate for compound 3 lay 2.2-fold (0.34 log units) above the measured number, within the range that was stated.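

In this assay the change to ethoxycarbonyl gives a 1.6-fold lower number from compound 2 to compound 3 (0.20 log units; within the scatter). Among the compounds shown here, this is the first pair to test the hydrogen-bond donor directly: methanesulfonamido has one, ethoxycarbonyl has none, and the nitrogen and sulfur also leave, so in this one pair a donor at this place is not needed for a number in this range. Compound 1 gives 50.1 nM; 50.1 nM (2 entries) and compound 3 gives 50.1 nM, the same printed figure from two different groups on the outer ring, so all three groups shown at this place remain within the usual scatter of their neighbours. Nothing measured here explains why the number holds across these groups.

Still open, on these data alone, is whether this tolerance reaches beyond groups of this kind: a carboxylic acid or a primary amine at this place would test that, and a longer chain such as butoxycarbonyl would test size. The shared core is also unchanged throughout, so these compounds say nothing about a substituent elsewhere on either ring.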